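Replacing the phenylethenyl arm with a dimethoxyphenyl ring

The source may report more compounds than this note shows. Statements on the series, on what has been measured and on what is new or still open speak of the compounds shown alone.

Measured compounds:
Compound 1, `Cc1cc(O)c(C2=NN(c3ccc(S(N)(=O)=O)cc3)C(c3ccccc3O)C2)cc1Cl`: in a functional assay on SN12C cells (Homo sapiens) for antiproliferative activity, with a stated time of 48 h (on this read-out higher numbers stand for weaker inhibition of growth and lower numbers for stronger inhibition of growth), compound 1 gives 4080 nM.
Compound 2, `Cc1cc(O)c(C2=NN(c3ccc(S(N)(=O)=O)cc3)C(c3ccccc3Cl)C2)cc1Cl`: compound 2 gives 2550 nM.
Compound 3, `Cc1cc(O)c(C2=NN(c3ccc(S(N)(=O)=O)cc3)C(/C=C/c3ccccc3)C2)cc1Cl`: compound 3 gives 11100 nM.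

Compound 3 carries a 2-phenylethenyl group on a saturated ring carbon of the shared core, the position that holds 2-hydroxyphenyl in compound 1 and 2-chlorophenyl in compound 2. Among the three measured compounds it gives the highest number in this assay: there is a 2.7-fold higher number from compound 1 to compound 3 (0.43 log units; beyond the scatter) and a 4.4-fold higher number from compound 2 to compound 3 (0.64 log units; beyond the scatter), both beyond the scatter, whereas a 1.6-fold lower number from compound 1 to compound 2 (0.20 log units; within the scatter).

Compound 4, `COc1ccc(C2CC(c3cc(Cl)c(C)cc3O)=NN2c2ccc(S(N)(=O)=O)cc2)cc1OC`, has not yet been measured. It differs from compound 3 in one place: 3,4-dimethoxyphenyl in place of 2-phenylethenyl on a saturated ring carbon. The two steps that bear on this change are the ones leading into compound 3, each of which saw an aromatic ring on that carbon replaced by the phenylethenyl group with a modest rise in the number. Within the data shown here, compound 4 returns an aromatic ring to that carbon, although one bearing two methoxy groups, for which no measured compound gives guidance. A modest step back down is expected, a 3.2-fold lower number from compound 3 to compound 4 (0.50 log units; beyond the scatter). Compound 4 is thus expected to give 3500 nM, with a range from 1500 nM to 9000 nM.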

Compound 4, concentration for 50% growth inhibition: 3700 nM
Compound 4: middle estimate off by 1.1-fold (0.02 log units), on the low side; low and high end bracket the measured number.
By their numbers in this assay, from the lowest: compounds 2, 4 and 1 (each within the scatter of the next); then compound 3.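

In this assay, 3,4-dimethoxyphenyl on the saturated ring carbon gives a 3.0-fold lower number from compound 3 to compound 4 (0.48 log units; beyond the scatter), the first measured step away from 2-phenylethenyl, and it shows that the earlier rise in the number can be reversed by a ring that carries neither hydroxy nor chloro. Compound 4 also stays close to the other two compounds with an aromatic ring at this position, with a 1.5-fold higher number from compound 2 to compound 4 (0.16 log units; within the scatter) and a 1.1-fold lower number from compound 1 to compound 4 (0.04 log units; within the scatter), so 3,4-dimethoxyphenyl, 2-chlorophenyl and 2-hydroxyphenyl cannot be told apart in this read-out. Among these four compounds, then, only 2-phenylethenyl stands apart at this carbon, and the larger substituent pattern of compound 4 brings no measurable loss against compound 1 or compound 2.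

No measurement offered here accounts for why compound 3 stands apart from the three compounds with an aromatic ring. The compounds shown leave open whether an unsubstituted phenyl, a cyclohexyl ring or a phenyl ring bearing an amine or a carboxylic acid at this carbon would match the aromatic rings measured here or compound 3.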